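Chloro substitution in an aryl urea quinazoline series

The compounds below may be only part of what the source reports. "The series", "measured", "known", "first", "only" and "open" are said of these compounds alone.

Measured so far:
Compound 1 `COc1cc2c(Nc3ccc(NC(=O)Nc4ccccc4)cc3)ncnc2cc1OCc1ccccc1`: > 50000 nM
Compound 2 `COc1cc2c(Nc3ccc(NC(=O)Nc4cccc(Cl)c4)cc3)ncnc2cc1OCc1ccccc1`: > 50000 nM
Compound 3 `COc1cc2c(Nc3ccc(NC(=O)Nc4ccccc4)cc3)ncnc2cc1OCCCN1CCN(C)CC1`: 49400 nM

In a functional assay on HT-29 cells (Homo sapiens) for antiproliferative activity, read by MTT assay, with a stated time of 48 h (on this read-out higher numbers stand for weaker inhibition and lower numbers for stronger inhibition), compound 1 gives > 50000 nM, which is a limit of the assay and not a number. Compound 2 gives > 50000 nM, also a limit. Among the measured compounds shown here, compound 3 gives 49400 nM, the only number among the three. The values of compound 1 and compound 2 are limits of the assay (the limit of > 50000 nM in this assay, at which 2 of the 3 values shown sit).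

Compound 1 and compound 2 differ by chloro in place of hydrogen on an aromatic carbon. The step that the two limits leave unreadable from compound 1 to compound 2 cannot be read, since both values are limits. The two cores differ by 2-(4-methylpiperazin-1-yl)ethyl in place of phenyl on a saturated chain carbon bound to an oxygen on an aromatic ring, with an at least 1.0-fold lower number from compound 1 to compound 3 (0.00 log units; that floor lies within the scatter).

Compound 4 `COc1cc2c(Nc3ccc(NC(=O)Nc4ccccc4)c(Cl)c3)ncnc2cc1OCCCN1CCN(C)CC1` is to be measured. It differs from compound 3 by chloro in place of hydrogen on an aromatic carbon. Its place line adds "ortho to a (phenylcarbamoyl)amino group", so this is the same kind of change as that from compound 1 to compound 2, not the same one.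

With compound 3 at 49400 nM and the earlier step unreadable, compound 4 is expected to show a 1.1-fold lower number from compound 3 to compound 4 (0.04 log units; within the scatter), essentially no shift. The estimate for compound 4 is 45000 nM, between 15000 nM and 60000 nM, with a real chance that only a limit is reported.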

Compound 4, half-maximal inhibitory concentration: 17300 nM
The estimate for compound 4 lay 2.6-fold (0.42 log units) above the measured number; the range from low to high includes it.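

In this assay, chloro in place of hydrogen on an aromatic carbon, ortho to a (phenylcarbamoyl)amino group, gives a 2.9-fold lower number from compound 3 to compound 4 (0.46 log units; beyond the scatter), a modest step on the core of compound 3. No second readable instance stands beside it, since the step from compound 1 to compound 2 cannot be read, both of its values being limits of the assay: the limit of > 50000 nM in this assay, at which 2 of the 4 values shown sit. The result therefore shows that chloro can lower the number on this one core at this one place, but it does not show that the change carries over to the core of compound 1, and the chloro of compound 2 sits at a different place in any case.

As far as these compounds go, it remains open whether fluoro or trifluoromethyl at the place of that chloro would give a similar step on the core of compound 3. Also open, from the compounds shown here alone, is whether the step would hold with a morpholine in place of the 4-methylpiperazine at the end of the chain.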